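This account rests on a few compounds, and the source may have more. Where it says the series, first, only, none or still open, it means among the compounds named here.

Working notes on the series. Compound 1 `OCCC(NC1CCN(CCCc2c[nH]c3ccc(-n4cnnc4)cc23)CC1)c1ccccc1` gives 5.1 nM in an assay on CHO cells for agonist activity at 5-hydroxytryptamine receptor 1D (Homo sapiens), read by GTPgammaS binding (on this read-out lower numbers stand for an effect already at smaller amounts and higher numbers for an effect only at larger amounts of compound), and sits second highest of the three numbers. Compound 3 `CC(=O)Nc1ccc(CNC2CCN(CCCc3c[nH]c4ccc(-n5cnnc5)cc34)CC2)cc1` gives 5 nM, with a 1.0-fold lower number from compound 1 to compound 3 (0.01 log units; within the scatter); compound 2 `NC(=O)OC[C@H](NC1CCN(CCCc2c[nH]c3ccc(-n4cnnc4)cc23)CC1)c1ccccc1` gives 9.3 nM, with a 1.8-fold higher number from compound 1 to compound 2 (0.26 log units; within the scatter). Compound 4 `CN(Cc1ccsc1)C1CCN(CCCc2c[nH]c3ccc(-n4cnnc4)cc23)CC1` is not yet measured; it differs from compound 1 by methyl((thiophen-3-yl)methyl)amino in place of (3-hydroxy-1-phenylpropyl)amino on a saturated ring carbon. For the measured compounds named here, both measured steps from compound 1 exchange the group on the same amine nitrogen, and each stays within the scatter, so no step beyond the scatter is expected here either, with the caveat that the entering group removes the donors of the leaving one, which no measured pair covers. For compound 4 the expected result is 7 nM, range 2 nM to 25 nM, an expected step of a 1.4-fold higher number from compound 1 to compound 4 (0.14 log units; within the scatter).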

Compound 4, half-maximal effective concentration: 4.2 nM
The estimate for compound 4 lay 1.7-fold (0.22 log units) above the measured number, within the range that was stated.
By their numbers in this assay, from the lowest: compounds 4, 3, 1 and 2 (each within the scatter of the next, the first and the last beyond it).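

In this assay, methyl((thiophen-3-yl)methyl)amino in place of (3-hydroxy-1-phenylpropyl)amino gives a 1.2-fold lower number from compound 1 to compound 4 (0.08 log units; within the scatter). For the compounds shown here, this step covers what the earlier pairs did not: a group with 0 hydrogen-bond donors and a five-membered aromatic ring replaces one with 2 donors and a six-membered aromatic ring of carbon only, and the number stays within the scatter. No measurement available here accounts for this result. The methyl and the thiophen-3-yl change together, so their separate contributions cannot be read. Going by these compounds, whether a carboxylic acid or a longer alkyl chain at this place would also stay within the scatter remains open.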